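The source may report more compounds than this note shows. Statements on the series, on what has been measured and on what is new or still open speak of the compounds shown alone.

Working notes on the series. Compound 1 `COCCNC(=O)[C@@H]1CC[C@@H](Nc2ncc3c(Br)nn(-c4ccc5ncccc5c4)c3n2)C1` carries a (2-methoxyethyl)carbamoyl group on a saturated ring carbon of the shared core, and in an assay on SK-OV-3 cells for inhibition of eIF-2-alpha kinase GCN2 (Homo sapiens) (a higher number here means a weaker inhibitor, a lower number a stronger inhibitor), compound 1 gives 20 nM. Compound 2 `COCCC(=O)N[C@@H]1CC[C@@H](Nc2ncc3c(Br)nn(-c4ccc5ncccc5c4)c3n2)C1` differs only at that carbon, and in this assay compound 2 gives 159 nM; the step is an 8.0-fold higher number from compound 1 to compound 2 (0.90 log units; beyond the scatter). Among the measured compounds shown here, of the two numbers so far, compound 2 holds the higher one, separated from compound 1 beyond the scatter. Compound 3 `Brc1nn(-c2ccc3ncccc3c2)c2nc(N[C@@H]3CC[C@@H](c4ncc[nH]4)C3)ncc12` is not yet measured; relative to compound 2 the change is 1H-imidazol-2-yl in place of ((2-methoxyethyl)carbonyl)amino on a saturated ring carbon. For the measured compounds named here, only one measured step touches this carbon, the modest one recorded from compound 1 to compound 2, which shows that reshaping the group there moves the number but not far. Going by the values given here, no measured pair covers an aromatic ring at this position, so the direction is open. The step from compound 2 to compound 3 is expected to be a 2.0-fold lower number from compound 2 to compound 3 (0.30 log units; within the scatter). Compound 3 is therefore estimated at 80 nM, with a range from 20 nM to 320 nM.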

Compound 3, half-maximal inhibitory concentration: 545 nM
For compound 3 the middle estimate is 6.8-fold (0.83 log units) below the measured one; measured number outside the range, above it.
By their numbers in this assay, from the lowest: compound 1; then compound 2; then compound 3.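

At this saturated ring carbon, an aromatic ring in place of an open chain carries the number further up, with a 3.4-fold higher number from compound 2 to compound 3 (0.53 log units; beyond the scatter) and, against the (2-methoxyethyl)carbamoyl group, a 27-fold higher number from compound 1 to compound 3 (1.44 log units; beyond the scatter). In this assay, the two replacements for the (2-methoxyethyl)carbamoyl group both give higher numbers beyond the scatter, so among these three groups the position favours that one, and the 1H-imidazol-2-yl group does not recover what ((2-methoxyethyl)carbonyl)amino lost. No measurement at hand accounts for these steps.

The compounds shown do not separate the contribution of the carbonyl from that of the 2-methoxyethyl chain, which a plain primary carboxamide or a carboxylic acid at this carbon would address. They also leave open whether a simple amine or a six-membered aromatic ring such as pyridine would follow the 1H-imidazol-2-yl group or the (2-methoxyethyl)carbamoyl group.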